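The source may report more compounds than this note shows. Statements on the series, on what has been measured and on what is new or still open speak of the compounds shown alone.

Measured so far:
- Compound 1 `CC(C)=CCC/C(C)=C/Cn1cc(-c2ccccc2)nn1`, which in a physicochemical assay for lipophilicity, measured as octanol-water partition (a lower number here means a more polar compound, a higher number a more lipophilic compound), gives 4.91
- Compound 2 `CCCc1cn(CC=C(C)C)nn1`, which gives 2.47
- Compound 3 `COC(=O)c1cn(C/C=C(\C)CCC=C(C)C)nn1`, which gives 3.2

Among the compounds with values here, compound 3 stands second highest of the three numbers in this assay: compound 2 lies lower, compound 1 lies higher, and the one single-point step recorded, a number 1.71 log units lower from compound 1 to compound 3 (beyond the scatter), is large. Compound 4 `COC(=O)c1cn(C/C=C(/C)CCC=C(C)C)nn1` differs from compound 3 in one respect only: the two compounds have the same atoms and bonds and differ only in configuration as drawn: 1 of 1 stereo elements differ; a double bond is drawn E in compound 3 and Z in compound 4. Within the data shown here, no measured step concerns a change of double-bond geometry alone, and the step from compound 1 to compound 3 involves a different change, so it does not bear on this one. Compound 4 is therefore expected to show no step beyond the scatter, no change at the digits printed from compound 3 to compound 4 (within the scatter). The estimate for compound 4 is 3.2, with a range from 2.85 to 3.55.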

Compound 4, partition coefficient: 3.2
For compound 4 middle estimate and measured number coincide at the digits printed; the range from low to high includes it.
By their numbers in this assay, from the lowest: compound 2; then compounds 3 and 4 (each within the scatter of the next); then compound 1.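

Among the compounds shown, this is the only pair that isolates the geometry of the double bond, and in this assay it gives no change at the digits printed from compound 3 to compound 4 (within the scatter). With methoxycarbonyl on the aromatic carbon, drawing the double bond E or Z therefore leaves the partition number unmoved, whereas the earlier step concerned only a change of group on that carbon. The comparison is a clean one: the fact that compounds 3 and 4 differ only in the configuration as drawn

As far as these compounds go, whether the same holds with the phenyl of compound 1 on that carbon remains open. The compounds shown also do not tell whether it holds with a carboxylic acid or an amide there.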